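The source may hold more compounds than are shown below. What is called first, only, known or untested is meant among the compounds shown, and "the series" means these compounds.

Measured in a functional assay on CCRF-CEM cells (Homo sapiens) for antiproliferative activity, read by sulforhodamine B assay, with a stated time of 48 h; on this read-out lower numbers stand for stronger inhibition and higher numbers for weaker inhibition:
- compound 1 `Cc1cc(C)cc(NS(=O)(=O)c2ccc(N3CCNC3=O)cc2)c1`: 170 nM
- compound 2 `O=C1NCCN1c1ccc(S(=O)(=O)Nc2cccc(Cl)c2)cc1`: 77 nM

Of these two, compound 2 holds the lower number, at 77 nM. Compound 3 `COc1cccc(NS(=O)(=O)c2ccc(N3CCNC3=O)cc2)c1` differs from it by one change: methoxy in place of chloro on an aromatic carbon. This puts methoxy in place of chloro on an aromatic carbon, meta to a large group. Going by the values given here, only one measured step alters this part of the molecule, a 2.2-fold lower number from compound 1 to compound 2 (0.34 log units; beyond the scatter), and it is modest. The data hold no direct comparison for methoxy, so a similarly modest rise is expected in this assay. The expected change is a 1.8-fold higher number from compound 2 to compound 3 (0.26 log units; within the scatter). Compound 3 is estimated at 140 nM, with an expected range of 50 nM to 400 nM.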

Compound 3, half-maximal inhibitory concentration: 260 nM
Compound 3: the middle estimate sits 1.9-fold (0.27 log units) below what was measured; the measured number falls inside the stated range.
By their numbers in this assay, from the lowest: compound 2; then compounds 1 and 3 (each within the scatter of the next).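

In this assay, the exchange of chloro for methoxy on this aromatic carbon, meta to a large group, gives a 3.4-fold higher number from compound 2 to compound 3 (0.53 log units; beyond the scatter), so the 3-chlorophenyl group holds its lead over a second replacement as well as the first. The 3-methoxyphenyl and 3,5-dimethylphenyl groups stay together, with a 1.5-fold higher number from compound 1 to compound 3 (0.18 log units; within the scatter), and the data do not separate them. Nothing measured here accounts for these differences.

The compounds shown leave open how a fluoro, an amine or a carboxylic acid would read at this carbon.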